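Chloro Substitution and Dose in a Small Anilide Series

The source may hold more compounds than are shown below. What is called first, only, known or untested is meant among the compounds shown, and "the series" means these compounds.

Compound 1 `CCC(=O)N(c1ccc(F)cc1)C1CCCC1N(C)C` was tested in a functional assay on the whole organism for positive allosteric modulation, with Mus musculus as the target; a lower number here means that less compound is needed, a higher number that more compound is needed for the effect. In that assay compound 1 gives only a limit, > 50 mg/kg. Compound 2 `CCC(=O)N(c1ccc(F)c(Cl)c1)C1CCCC1N(C)C` differs from it by chloro in place of hydrogen on an aromatic carbon, and in this assay compound 2 gives 0.7 mg/kg, so that the step is an at least 71-fold lower number from compound 1 to compound 2 (1.85 log units; beyond the scatter). Compound 3 `CCC(=O)N(c1cc(Cl)cc(Cl)c1)C1CCCC1N(C)C` has a core whose difference from that of compound 1 is not broken down here; in this assay compound 3 gives 30 mg/kg, the highest of the two numbers measured.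

Compound 4 `CCC(=O)N(c1cc(Cl)c(Cl)c(Cl)c1)C1CCCC1N(C)C` is not yet measured. It differs from compound 3 by chloro in place of hydrogen on an aromatic carbon. This is the same kind of change as from compound 1 to compound 2, though the place is not the same: here the entering chloro sits ortho to two chloro groups and para to a large group, whereas before it sat ortho to a fluoro group and meta to a large group. Because the earlier step was an at least 71-fold lower number from compound 1 to compound 2 (1.85 log units; beyond the scatter), a lower number is expected here too. The step is expected to be smaller, estimated as a 3.8-fold lower number from compound 3 to compound 4 (0.57 log units; beyond the scatter). The evidence for this rests on a single step at a different place. Compound 4 is therefore estimated at 8 mg/kg, between 1.5 mg/kg and 50 mg/kg.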

Compound 4, dose for half-maximal effect: 40 mg/kg
Compound 4: the middle estimate sits 5.0-fold (0.70 log units) below what was measured, within the range that was stated.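

In this assay, chloro in place of hydrogen on an aromatic carbon gives a 1.3-fold higher number from compound 3 to compound 4 (0.12 log units; within the scatter), so the large step seen on the core of compound 1 does not reappear on the core of compound 3, and the two steps differ: the same change on two cores in this assay, an at least 71-fold lower number (1.85 log units; beyond the scatter) from compound 1 to compound 2 and a 1.3-fold higher number (0.12 log units; within the scatter) from compound 3 to compound 4, at least 95-fold (1.97 log units) apart, beyond the scatter of two such steps. This shows that the change does not carry over as a fixed step between these two cores, but it does not show whether the core is what matters, since the entering chloro in compound 4 also sits at another place, ortho to two chloro groups and para to a large group. The size of the earlier step is itself known only as a bound, its starting value being a limit of the assay: the limit of > 50 mg/kg in this assay, at which 1 of the 4 values shown sits.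

The compounds shown leave open whether a bromo or a methoxy group in place of the entering chloro would give a different step in this assay. Also open, from the compounds shown here alone, is whether a longer chain on the carbonyl, or a primary amine in place of the dimethylamino group, would alter the step that chloro gives.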